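Halogen Swap on a Chalcone: Chloro to Bromo

A few compounds are considered here, and "the series" means these few. Any claim that something is new, unique, unknown or untested is made for them only; others in the source may bear on it.

Measured so far:
compound 1 `COc1cc(OC)c(C(=O)/C=C/c2ccccc2)c(OC)c1` gives 4.5%;
compound 2 `COc1cc(O)c(C(=O)/C=C/c2ccccc2OC)c(OC)c1` gives 14%;
compound 3 `COc1cc(OC)c(C(=O)/C=C/c2ccc(Cl)cc2)c(OC)c1` gives 0%.

In a functional assay on NCI-H727 cells (Homo sapiens), read by fluorescence and BrdU incorporation, with a stated time of 48 h, tested at 25 uM (a lower number here means a stronger effect, a higher number a weaker effect of the compound at the concentration tested), compound 3 gives the lowest number of the three; its gap to compound 1 lies within the scatter, while compound 2 stands farther off, beyond it. Going by the values given here, the only single-point step recorded, a number 4.5 percentage points lower from compound 1 to compound 3 (within the scatter), brought no shift beyond the scatter. Compound 4 `COc1cc(OC)c(C(=O)/C=C/c2ccc(Br)cc2)c(OC)c1` differs from compound 3 by bromo in place of chloro on an aromatic carbon. Among the compounds with values here, no step from chloro to bromo has been measured here, so the expectation rests on the chloro step alone, which was small. The step from compound 3 to compound 4, a number 3 percentage points higher from compound 3 to compound 4 (within the scatter), is therefore expected to stay within the scatter. Compound 4 is estimated at 3%, with a range from 0% to 12%.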

Compound 4, a percentage reported as activity, at one concentration (the size of the read-out at that concentration, not a potency): 6%
Compound 4: middle estimate off by 3 percentage points, on the low side; measured number inside the range.
By their numbers in this assay, from the lowest: compounds 3, 1, 4 and 2 (each within the scatter of the next, the first and the last beyond it).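

In this assay the step of a number 6 percentage points higher from compound 3 to compound 4 (within the scatter) and the step of a number 1.5 percentage points higher from compound 1 to compound 4 (within the scatter) complete the set of comparisons at this position, para to a large group. Hydrogen, chloro and bromo there now all stand within the scatter of one another, whereas the earlier compounds had shown only the pair of hydrogen and chloro. Nothing given here accounts for this closeness. The compounds shown leave open whether an amine or a carboxylic acid in this place would move the number beyond the scatter.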